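The source may hold more compounds than are shown below. What is called first, only, known or untested is meant among the compounds shown, and "the series" means these compounds.

Of the compounds shown here, three built on one shared core have been measured in a physicochemical assay for lipophilicity; on this read-out lower numbers stand for lower lipophilicity and higher numbers for higher lipophilicity. Compound 1 `CN(C)c1ccc(/C=C2\CCC/C(=C\c3ccccc3[N+](=O)[O-])C2=O)cc1` gives 4.86. Compound 2 `O=C1/C(=C/c2ccc(F)cc2)CCC/C1=C\c1cccc([N+](=O)[O-])c1` gives 5.06 in this assay. Compound 3 `CN(C)c1ccc(/C=C2\CCC/C(=C\c3cccc([N+](=O)[O-])c3)C2=O)cc1` gives 5.06 in this assay. Compound 1 stands lowest of the three numbers, but the gaps are small: a number 0.20 log units higher from compound 1 to compound 3 (within the scatter), which lies within the scatter, and the value of compound 2 sits the same small distance above compound 1, so the three compounds cannot be told apart on this read-out.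

The unmeasured compound 4 `O=C1/C(=C/c2ccc(F)cc2)CCC/C1=C\c1ccccc1[N+](=O)[O-]` differs from compound 1 in one place: fluoro in place of dimethylamino on an aromatic carbon. The same exchange has been seen once already, in the opposite direction, between two measured compounds: no change at the digits printed from compound 2 to compound 3 (within the scatter). Within the data shown here, that step is the only direct guide, and it suggests that trading dimethylamino for fluoro on the aromatic carbon moves this assay by nothing beyond the scatter. The other measured step, a number 0.20 log units higher from compound 1 to compound 3 (within the scatter), concerns a different part of the molecule and is also small.

Compound 4 is therefore expected to land at about 4.86, with a likely range from 4.5 to 5.25. The expected step is no change at the digits printed from compound 1 to compound 4 (within the scatter), which is expected to stay within the scatter.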

Compound 4, partition coefficient: 4.86
Beside the measured number, compound 4's estimate shows no gap at the digits printed; low and high end bracket the measured number.
By their numbers in this assay, from the lowest: compounds 1, 4, 2 and 3 (each within the scatter of the next).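

In this assay, replacing dimethylamino with fluoro on the aromatic carbon gives no change at the digits printed from compound 1 to compound 4 (within the scatter), and this time the compounds carry 2-nitrophenyl. Among these compounds, until now the exchange had been seen only in compounds carrying 3-nitrophenyl, where the opposite direction gave no change at the digits printed from compound 2 to compound 3 (within the scatter), so the two pairs now agree: with either nitrophenyl group, the three-heavy-atom dimethylamino and the single-atom fluoro give values within the scatter of each other at this position. No measurement shown here explains this agreement.

Only these two groups have been compared at this position, so a carboxylic acid, a primary amine or a longer chain such as butyl could give a quite different number in this assay, and two pairs cannot show how far the agreement extends. The compounds also leave open whether dimethylamino and fluoro would stay this close with a group other than nitrophenyl elsewhere on the shared core, or on any read-out other than this assay.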